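The source may report more compounds than this note shows. Statements on the series, on what has been measured and on what is new or still open speak of the compounds shown alone.

Measured compounds:
compound 1, `CC[C@@H]1C(=O)N(C)c2cnc(-n3ccc4cc(F)ccc43)nc2N1C1CCCC1`, 46500 nM
compound 2, `CCCCNS(=O)(=O)c1ccc(Nc2ncc3c(n2)N(c2ccn(C)n2)C(CC)C(=O)N3C)cc1`, 4120 nM
compound 3, `CCC1C(=O)N(C)c2cnc(Nc3ccc(S(=O)(=O)NCCO)cc3)nc2N1c1ccn(C)n1`, "not active" (no number reported)

In a functional assay on NCI-H1975 cells (Homo sapiens) for antiproliferative activity, read by CCK-8 assay, with a stated time of 72 h (on this read-out lower numbers stand for stronger inhibition of growth and higher numbers for weaker inhibition of growth), compound 1 gives the higher of the two numbers that exist, and the gap to compound 2, whose value is 4120 nM, lies beyond the usual scatter, so compound 1 is the weaker of the two measured growth inhibitors. Compound 3 yields no number at all.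

Compound 4, `CC[C@@H]1C(=O)N(C)c2cnc(-n3ccc4cc(C(=O)NC5CCCC5)ccc43)nc2N1C1CCCC1`, keeps the whole core of compound 1 and changes one spot: cyclopentylcarbamoyl in place of fluoro on an aromatic carbon. Among the compounds with values here, no measured pair shows what such a replacement does on this core, so the expectation rests only on the starting point. Because compound 1 sits at 46500 nM, there is room for the number to fall, and the entering group is much larger than the leaving one, so a change beyond the scatter in either direction is plausible. A moderate move toward lower numbers is expected, a 3.1-fold lower number from compound 1 to compound 4 (0.49 log units; beyond the scatter), with wide uncertainty.

Compound 4 is therefore estimated at 15000 nM, in the range 3000 nM to 70000 nM.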

Compound 4, concentration for 50% growth inhibition: 856 nM
For compound 4 the middle estimate is 18-fold (1.24 log units) above the measured one; the measured number lies below the stated range.
By their numbers in this assay, from the lowest: compound 4; then compound 2; then compound 1.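

In this assay, the aromatic carbon that carries fluoro in compound 1 proves to be a position where a change matters: cyclopentylcarbamoyl in its place gives a 54-fold lower number from compound 1 to compound 4 (1.73 log units; beyond the scatter), a large step beyond the usual scatter. Within the data shown here, this carbon therefore tolerates a much larger group, and growth inhibition becomes stronger rather than being lost, something the earlier compounds could not show, as no two of them differed in one place only. Nothing measured here explains the gain.

Going by these compounds, it remains open whether the gain needs the cyclopentyl ring or only the carbamoyl part; a carboxylic acid, an unsubstituted carbamoyl group or a cyclohexylcarbamoyl group on the same carbon would help separate the two. On these data alone, it is also open whether the same replacement would give a similar step on a different core.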